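The source may hold more compounds than are shown below. What is called first, only, known or untested is meant among the compounds shown, and "the series" means these compounds.

Measured compounds in the series:
compound 1 `CC(C)COc1nc(C(C)(C)C)ccc1CNC(=O)C(C)c1ccc(NS(C)(=O)=O)c(F)c1`, 0.6 nM
compound 2 `CC(C(=O)NCc1ccc(C(C)(C)C)nc1OCc1ccc(F)cc1)c1ccc(NS(C)(=O)=O)c(F)c1`, 0.8 nM
compound 3 `CCCCCSc1nc(C(C)(C)C)ccc1CNC(=O)C(C)c1ccc(NS(C)(=O)=O)c(F)c1`, 3.1 nM

In an assay on cells for antagonist activity at transient receptor potential cation channel subfamily V member 1 (Homo sapiens), read by FLIPR and calcium flux, with a stated time of 6 min (a higher number here means a weaker inhibitor, a lower number a stronger inhibitor), compound 1 gives the lowest of the three numbers. Its nearest neighbour is compound 2, a 1.3-fold higher number from compound 1 to compound 2 (0.12 log units; within the scatter), so the two cannot be separated; the furthest is compound 3, a 5.2-fold higher number from compound 1 to compound 3 (0.71 log units; beyond the scatter).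

Compound 4 `CC(C(=O)NCc1ccc(C(C)(C)C)nc1SCCCN1CCCC1)c1ccc(NS(C)(=O)=O)c(F)c1` differs from compound 1 in one place: (3-(pyrrolidin-1-yl)propyl)sulfanyl in place of isobutoxy on an aromatic carbon. The measured step that bears most directly on this change runs from compound 1 to compound 3, a 5.2-fold higher number from compound 1 to compound 3 (0.71 log units; beyond the scatter), where a sulfur-linked chain replaced the isobutoxy on the same aromatic carbon. The step from compound 2 to compound 3, a 3.9-fold higher number from compound 2 to compound 3 (0.59 log units; beyond the scatter), points the same way. Among the compounds with values here, compound 4 again carries a sulfur-linked chain, now ending in a pyrrolidine ring; no measured pair shows what that ring end does on its own. The expectation for compound 4 in this assay is therefore a modest loss of the same order, a 5.0-fold higher number from compound 1 to compound 4 (0.70 log units; beyond the scatter). Compound 4 is estimated at 3 nM, within a range of 1 nM to 10 nM.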

Compound 4, inhibition constant: 17.1 nM
Compound 4: the middle estimate sits 5.7-fold (0.76 log units) below what was measured; measured number outside the range, above it.
By their numbers in this assay, from the lowest: compounds 1 and 2 (each within the scatter of the next); then compound 3; then compound 4.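

With the sulfur link held constant, pyrrolidin-1-yl in place of ethyl in this assay gives a 5.5-fold higher number from compound 3 to compound 4 (0.74 log units; beyond the scatter) and so shows that the chain end counts apart from the sulfur link. The full replacement gives a 29-fold higher number from compound 1 to compound 4 (1.45 log units; beyond the scatter) and also a 21-fold higher number from compound 2 to compound 4 (1.33 log units; beyond the scatter), both large, whereas the earlier changes at this aromatic carbon stayed modest or within the scatter. Nothing available here explains the further loss from the pyrrolidine end.

From the compounds shown here alone, whether that loss belongs to the pyrrolidine ring or to any amine at the chain end stays open, and a morpholine ring or a dimethylamino group on the same propyl chain would separate the two. Also open, going by these compounds, is how much of the loss depends on the sulfur link, which the 3-(pyrrolidin-1-yl)propoxy group would test.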